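A phenylpiperazine in place of the thiadiazolyl thioether

The source may report more compounds than this note shows. Statements on the series, on what has been measured and on what is new or still open speak of the compounds shown alone.

Among the three measured compounds, compound 2 `Cc1nnc(SCC(=O)Nc2ccc(-c3nc(-c4ccccc4)c(-c4ccccc4)n3C)cc2)s1` stands highest in a functional assay on MCF7 cells (Homo sapiens) for cytotoxicity, read by MTT assay, with a stated time of 24 h, tested at 32 ug/mL (a lower number here means a weaker effect, a higher number a stronger effect of the compound at the concentration tested), where compound 2 gives 83.4%. Compound 1 `Cn1c(-c2ccc(NC(=O)CSc3nc4cc(Cl)ccc4o3)cc2)nc(-c2ccccc2)c1-c1ccccc1` gives 59.7%, and compound 3 `CN1CCN(CC(=O)Nc2ccc(-c3nc(-c4ccccc4)c(-c4ccccc4)n3C)cc2)CC1` gives 46.2%, so that a number 23.7 percentage points higher from compound 1 to compound 2 (beyond the scatter) and a number 37.2 percentage points lower from compound 2 to compound 3 (beyond the scatter), both beyond the scatter. Compound 4 `Cn1c(-c2ccc(NC(=O)CN3CCN(c4ccccc4)CC3)cc2)nc(-c2ccccc2)c1-c1ccccc1` is not yet measured; it differs from compound 2 by 4-phenylpiperazin-1-yl in place of (5-methyl-1,3,4-thiadiazol-2-yl)sulfanyl on a saturated chain carbon bound to a carbonyl carbon. For the measured compounds named here, the step most closely related is the one to compound 3, which also puts a piperazin-1-yl group on that chain carbon and fell by a number 37.2 percentage points lower from compound 2 to compound 3 (beyond the scatter); the step of a number 13.5 percentage points lower from compound 1 to compound 3 (beyond the scatter) points the same way. Going by the values given here, compound 4 carries a phenyl rather than a methyl on the piperazine, a change for which no measured pair gives guidance. The step is therefore expected to be downward, with a size estimated as a number 28.4 percentage points lower from compound 2 to compound 4 (beyond the scatter). Compound 4 is expected to give about 55% in this assay, within a range from 35% to 75%.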

Compound 4, a percentage reported as activity, at one concentration (the size of the read-out at that concentration, not a potency): 63.6%
Compound 4: the middle estimate sits 8.6 percentage points below what was measured; low and high end bracket the measured number.
By their numbers in this assay, from the lowest: compound 3; then compounds 1 and 4 (each within the scatter of the next); then compound 2.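

In this assay, the group on the piperazine nitrogen proves to matter, with a number 17.4 percentage points higher from compound 3 to compound 4 (beyond the scatter) for phenyl in place of methyl on an amine nitrogen in a ring, so the piperazine alone does not set the read-out at this chain carbon. The 4-phenylpiperazin-1-yl group still falls short of the (5-methyl-1,3,4-thiadiazol-2-yl)sulfanyl group, with a number 19.8 percentage points lower from compound 2 to compound 4 (beyond the scatter), but it cannot be told apart from the (5-chloro-1,3-benzoxazol-2-yl)sulfanyl group, with a number 3.9 percentage points higher from compound 1 to compound 4 (within the scatter) in this comparison. No evidence is available here to explain these differences.

Still open, as far as these compounds go, is whether a benzyl or a pyridin-2-yl group on the piperazine nitrogen would go beyond phenyl, and whether a chloro or methoxy group on that phenyl would shift the read-out. From the compounds shown here alone, it is also open whether a morpholine in place of the piperazine would keep the read-out of compound 4.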